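A few compounds are considered here, and "the series" means these few. Any claim that something is new, unique, unknown or untested is made for them only; others in the source may bear on it.

Measured compounds:
compound 1 `CCCn1c(=O)n(CCOCC)c(=O)c2[nH]cnc21` — 1900 nM
compound 2 `C=CCCn1cnc2c1c(=O)n(C)c(=O)n2CCC` — 6000 nM

In an assay on Cerebral cortex for binding affinity to adenosine receptor A1 (Cavia porcellus), read by radioligand binding (on this read-out lower numbers stand for stronger inhibition and higher numbers for weaker inhibition), compound 1 gives 1900 nM. In this assay compound 2 gives 6000 nM, the highest of the two numbers; its gap to compound 1 lies beyond the usual scatter, so compound 2 is the weaker binder of this pair. Among the compounds with values here, no step between two measured compounds that differ in a single place is available, so the weight of any one change cannot be read from the measured set.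

Compound 3 `CCCn1c(=O)n(C)c(=O)c2c1ncn2CC(C)=O` is not yet measured in this assay. It differs from compound 2 in one place: acetyl in place of allyl on a saturated chain carbon bound to an aromatic nitrogen. Within the data shown here, with no matched step to lean on, the expectation for compound 3 rests only on compound 2 at 6000 nM. The expected step is small, a 1.3-fold higher number from compound 2 to compound 3 (0.12 log units; within the scatter), toward a weaker number or none beyond the scatter. Compound 3 is estimated at 8000 nM, with a range from 3000 nM to 25000 nM.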

Compound 3, inhibition constant: 95700 nM
The estimate for compound 3 lay 12-fold (1.08 log units) below the measured number; measured number outside the range, above it.
By their numbers in this assay, from the lowest: compound 1; then compound 2; then compound 3.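

In this assay, within the data shown here, the saturated chain carbon bound to an aromatic nitrogen proves sensitive to the group it carries: acetyl in place of allyl gives a 16-fold higher number from compound 2 to compound 3 (1.20 log units; beyond the scatter) and is the only single-place step so far. The two groups have the same heavy-atom count and each has a double bond outside aromatic rings, so that count and that double bond do not separate them; they differ in an oxygen for a carbon and in the hydrogen-bond acceptor that acetyl brings and allyl lacks. No measurement at hand explains the size of this step.

From the compounds shown here alone, whether a longer chain, an amine or a carboxylic acid at this place would stay near compound 2 or fall toward compound 3 remains open. Also open, going by these compounds, is whether the same change would carry the same weight on the core of compound 1.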